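This account rests on a few compounds, and the source may have more. Where it says the series, first, only, none or still open, it means among the compounds named here.

Of the compounds shown here, two have been measured in a functional assay on A-375 cells (Homo sapiens) for antiproliferative activity, read by MTT assay, with a stated time of 48 h; a lower number here means a stronger inhibitor, a higher number a weaker inhibitor. Compound 1 `Nc1nc(CC2CCCCC2)c(-c2ccccc2Br)n1CC(=O)Nc1ccccc1` gives 40600 nM in this assay. Compound 2 `CCCCCc1nc(N)n(CC(=O)Nc2ccc(C)cc2)c1-c1ccccc1Br` gives 4300 nM in this assay, the lower of the two numbers, and the gap to compound 1 lies beyond the scatter. Among the compounds with values here, compound 1 and compound 2 differ in two places at once, so no single step between them can be read.

Compound 3 `COc1ccc(Cc2nc(N)n(CC(=O)Nc3ccc(C)cc3)c2-c2ccccc2Br)cc1` carries the change (4-methoxyphenyl in place of butyl on a saturated chain carbon bound to an aromatic carbon). Nothing measured here isolates that change, so its effect cannot be read from a known step. Compound 3 is therefore expected to stay near compound 2, with the estimated step from compound 2 to compound 3 being a 1.4-fold higher number from compound 2 to compound 3 (0.14 log units; within the scatter), small and not clearly beyond the scatter in either direction. For compound 3 the estimate in this assay is 6000 nM, with a range from 1500 nM to 25000 nM.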

Compound 3, half-maximal inhibitory concentration: 2400 nM
The estimate for compound 3 lay 2.5-fold (0.40 log units) above the measured number, and the stated range covers the measured number.
By their numbers in this assay, from the lowest: compounds 3 and 2 (each within the scatter of the next); then compound 1.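

In this assay, within the data shown here, the first step that can be read is a 1.8-fold lower number from compound 2 to compound 3 (0.25 log units; within the scatter). At this saturated chain carbon bound to an aromatic carbon, butyl can therefore give way to 4-methoxyphenyl, bringing in a six-membered aromatic ring and a hydrogen-bond acceptor, with no difference that stands clear of the scatter. This single step offers no account of why the two compounds read alike, and no supporting evidence on that question is available.

The compounds shown leave open whether the ring or the methoxy group contributes anything on its own, a question that plain phenyl at this place would address. They also leave open whether a longer chain, an amine or a carboxylic acid would be accommodated here as well.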